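The source may report more compounds than this note shows. Statements on the series, on what has been measured and on what is new or still open speak of the compounds shown alone.

The series rests on one shared core, carried by compound 1 `Cc1cc(C(=O)Nc2ccc(F)cc2)nn1-c1cccc(C(F)(F)F)c1`, compound 2 `Cc1cc(C(=O)Nc2cc(Cl)cc(Cl)c2)nn1Cc1ccccc1` and compound 3 `Cc1cc(C(=O)Nc2cc(Cl)cc(Cl)c2)nn1-c1ccccc1C(F)(F)F`. Among the measured compounds shown here, in an assay on HEK293 cells for binding affinity to Neuropeptide Y receptor type 5 (Homo sapiens), read by radioligand binding (a higher number here means a weaker inhibitor, a lower number a stronger inhibitor), compound 1 gives 800 nM, and this is the only number among the three values shown. Compound 2 reaches only a limit of this assay, reported as > 1000 nM. Compound 3 likewise returns a limit, given as > 1000 nM. For the measured compounds named here, compound 2 and compound 3 each differ from compound 1 in two places at once, so no single step between measured compounds can be read from these three.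

Compound 4 `Cc1cc(C(=O)Nc2cc(Cl)cc(Cl)c2)nn1-c1cccc(C(F)(F)F)c1` has not yet been measured in this assay. It differs from compound 1 by 3,5-dichlorophenyl in place of 4-fluorophenyl on an amide-type nitrogen. The same amide substituent appears in compound 2 and compound 3, both of which stop at a limit, and compound 1 itself is already a weak binder. On that basis compound 4 is expected to lose rather than gain against compound 1, with an estimated step of a 2.0-fold higher number from compound 1 to compound 4 (0.30 log units; within the scatter) in this assay. For compound 4 the expected value in this assay is 1600 nM, within a range from 500 nM to 5000 nM. A reported limit rather than a number is thought likely because the limit of > 1000 nM in this assay, at which 2 of the 3 values shown sit, already holds two of the three values shown.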

Compound 4, half-maximal inhibitory concentration: 150 nM
Beside the measured number, compound 4's estimate is 11-fold (1.03 log units) above it; the measured number lies below the stated range.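

In this assay, among the compounds shown here, this is the first comparison that changes one place only, and it shows that the amide-type nitrogen responds to its substituent: 3,5-dichlorophenyl in place of 4-fluorophenyl gives a 5.3-fold lower number from compound 1 to compound 4 (0.73 log units; beyond the scatter). It also shows that a compound carrying 3,5-dichlorophenyl can return a measured number: compound 4 carries that group and gives 150 nM. Compound 2 and compound 3 carry the same amide substituent and each differ from compound 4 in the other aryl group only, but each is reported only as a limit, so the steps that would link them to compound 4 cannot be read: the limit of > 1000 nM in this assay, at which 2 of the 4 values shown sit.

With only two amide substituents among the compounds shown, it remains open whether 3-chlorophenyl, 3,5-difluorophenyl or 3,5-dimethylphenyl on the same nitrogen would behave like 3,5-dichlorophenyl or like 4-fluorophenyl. On these data alone, it is also open whether the step would hold if the 3-(trifluoromethyl)phenyl group of compound 4 gave way to a 3-chlorophenyl or a 3-methoxyphenyl group.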